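Lengthening a charged chain on a bradykinin receptor blocker

This account rests on a few compounds, and the source may have more. Where it says the series, first, only, none or still open, it means among the compounds named here.

Compound 3 `Cc1cc(C)c2cccc(OCc3c(Cl)ccc(S(=O)(=O)NC4(C(=O)N5CCN(C(=O)CCC[N+](C)(C)C)CC5)CCCC4)c3Cl)c2n1` carries a positively charged nitrogen at the end of a short saturated chain that is attached through a carbonyl. In an assay on isolated protein for binding affinity to B1 bradykinin receptor (Homo sapiens) (a lower number here means a stronger inhibitor, a higher number a weaker inhibitor), compound 3 gives < 10000 nM, which is a limit of the assay rather than a number. Compound 1 `Cc1cc(C)c2cccc(OCc3c(Cl)ccc(S(=O)(=O)NC4(C(=O)N5CCN(C(=O)[C@@H](N)CCCCN)CC5)CCCC4)c3Cl)c2n1` has an amino-acid-derived amide in place of that chain; in this assay compound 1 gives < 10000 nM, again only a limit. Compound 2 `Cc1cc(C)c2cccc(OCc3c(Cl)ccc(S(=O)(=O)NC4(C(=O)N5CCN(C(=O)CCCCC[N+](C)(C)C)CC5)CCCC4)c3Cl)c2n1` carries a longer charged chain, and in this assay compound 2 gives < 10000 nM, also a limit. Since (the limit of < 10000 nM in this assay, at which 3 of the 3 values shown sit), the steps between these three cannot be read in size: a step that the two limits leave unreadable from compound 1 to compound 3 and a step that the two limits leave unreadable from compound 2 to compound 3 are both hidden by the limits.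

Compound 4 `Cc1cc(C)c2cccc(OCc3c(Cl)ccc(S(=O)(=O)NC4(C(=O)N5CCN(C(=O)CCCC[N+](C)(C)C)CC5)CCCC4)c3Cl)c2n1` differs from compound 3 by a group of 5 heavy atoms (4 carbon, 1 nitrogen; no ring) in place of a group of 4 heavy atoms (3 carbon, 1 nitrogen; no ring), on a saturated chain carbon, three bonds along the chain from a carbonyl carbon, giving a chain longer than in compound 3 and shorter than in compound 2. The comparison that bears most directly on it is a step that the two limits leave unreadable from compound 2 to compound 3, whose size the limits conceal, so no direction can be drawn from the measured steps. Compound 4 is expected to sit at the same limit, with an estimated step that the limit leaves unreadable from compound 3 to compound 4 that stays within the scatter. The estimate for compound 4 is 1000 nM, within 100 nM to 10000 nM.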

Compound 4, inhibition constant: < 10000 nM
Compound 4: no number, only a limit (the forecaster's own chance of this, stated with the estimate: 70%); the middle value lies beyond the limit too.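

In this assay compound 4 gives < 10000 nM, which is a limit and not a number. The steps linking compound 4 with compound 1, compound 2 and compound 3 therefore cannot be read in size: the limit of < 10000 nM in this assay, at which 4 of the 4 values shown sit.

The compounds shown leave open how strongly each one binds, and whether the length of the charged chain makes any difference.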